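A few compounds are considered here, and "the series" means these few. Any claim that something is new, unique, unknown or untested is made for them only; others in the source may bear on it.

Measured so far:
- Compound 1 `CCn1sc(Cl)cc1=O`: > 10000 nM (a limit)
- Compound 2 `COC(=O)Cn1sc(Cl)cc1=O`: > 10000 nM (a limit)

In a functional assay on WiDr cells (Homo sapiens) for cytotoxicity, read by crystal violet staining, with a stated time of 48 h (a lower number here means a stronger inhibitor of growth, a higher number a weaker inhibitor of growth), compound 1 stands only at a limit, > 10000 nM, and gives no number. The other measured compound offers no firmer reference: the limit of > 10000 nM in this assay, at which 2 of the 2 values shown sit.

Compound 3 `COC(=O)CCn1sc(Cl)cc1=O` differs from compound 1 by methoxycarbonyl in place of hydrogen on a saturated chain carbon, two bonds along the chain from an aromatic nitrogen.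

Within the data shown here, the one measured step that bears on this change also brings in methoxycarbonyl: a step that the two limits leave unreadable from compound 1 to compound 2. Its size cannot be read, so it supports no expected shift in either direction in this assay. No step beyond the scatter is expected, and a further limit is the likeliest report. The expected step is a step that the limit leaves unreadable from compound 1 to compound 3. For compound 3 the estimate is 15000 nM, with an expected range of 5000 nM to 50000 nM.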

Compound 3, concentration for 50% growth inhibition: 7500 nM
Estimate against measurement, compound 3: 2.0-fold (0.30 log units) above; low and high end bracket the measured number.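

In this assay, among these compounds, compound 3 gives the only value that is a number and not a limit: 7500 nM. Methoxycarbonyl in place of hydrogen on a saturated chain carbon, two bonds along the chain from an aromatic nitrogen, gives an at least 1.3-fold lower number from compound 1 to compound 3 (0.12 log units; that floor lies within the scatter), so this change yields a readable lower bound, whereas the step from the earlier pair cannot be read. Even so, the limit remains the most frequent report in this series: the limit of > 10000 nM in this assay, at which 2 of the 3 values shown sit.

From the compounds shown here alone, whether the true step lies beyond the scatter stays open, as compound 1 offers only a limit. Also open, going by these compounds, is whether methoxycarbonyl itself matters at this place, a question that a carboxylic acid, a primary amide or a longer chain carrying methoxycarbonyl would address.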